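Swapping the Fluorophenyl for a Methylphenyl

The source may hold more compounds than are shown below. What is called first, only, known or untested is meant among the compounds shown, and "the series" means these compounds.

Compound 2 `Cc1cc(=O)n(-c2cccc(F)c2)nc1C(=O)Nc1ccc(Oc2ncnc3sccc23)cc1` carries a 3-fluorophenyl group on the shared core. Going by the values given here, in a functional assay on A549 cells (Homo sapiens) for cytotoxicity, read by MTT assay, with a stated time of 72 h (a higher number here means a weaker inhibitor, a lower number a stronger inhibitor), compound 2 gives 16400 nM, the higher of the two numbers so far, though within the scatter of compound 1. Among the compounds with values here, compound 1 `Cc1cc(=O)n(-c2ccccc2OC(F)(F)F)nc1C(=O)Nc1ccc(Oc2ncnc3sccc23)cc1` gives 15500 nM in this assay, and the one known step, a 1.1-fold higher number from compound 1 to compound 2 (0.02 log units; within the scatter), exchanged the group on that same nitrogen. Compound 3 `Cc1ccc(-n2nc(C(=O)Nc3ccc(Oc4ncnc5sccc45)cc3)c(C)cc2=O)cc1` differs from compound 2 by 4-methylphenyl in place of 3-fluorophenyl on an aromatic nitrogen. Because a 1.1-fold higher number from compound 1 to compound 2 (0.02 log units; within the scatter) stayed within the scatter, the step expected here, a 1.0-fold lower number from compound 2 to compound 3 (0.01 log units; within the scatter), is small. Compound 3 is estimated at about 16000 nM, between 6000 nM and 45000 nM.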

Compound 3, half-maximal inhibitory concentration: > 40000 nM
Compound 3 gave a limit, no number; the forecaster's own chance of this, stated with the estimate: 10%; at least 2.5-fold (0.39 log units) between middle value and limit.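

Compound 3 gives a limit of the assay, not a number: the limit of > 40000 nM in this assay, at which 1 of the 3 values shown sits.

Even so, both new steps lie beyond the scatter, an at least 2.4-fold higher number from compound 2 to compound 3 (0.38 log units; beyond the scatter) and an at least 2.5-fold higher number from compound 1 to compound 3 (0.41 log units; beyond the scatter), whereas the exchange between compound 1 and compound 2 stayed within it. The group on this nitrogen can therefore shift the reading, and 4-methylphenyl gives the weakest result of the three.

Going by these compounds, how far compound 3 lies past its limit stays unknown, as does whether the methyl group itself or its place on the ring counts. On these data alone, how a phenyl ring carrying an amine or a carboxylic acid would read in this assay also remains open.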